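Swapping the aryl on the triazole nitrogen: compound 4

The source may hold more compounds than are shown below. What is called first, only, known or untested is meant among the compounds shown, and "the series" means these compounds.

Three compounds share a core and differ only in the aryl group on the aromatic nitrogen. Compound 1 `CCc1ccc(-n2nc(-c3ccc(C(F)(F)F)cc3O)nc2-c2ccccc2O)cc1` gives 64.4% in a functional assay on PC-12 cells (Rattus norvegicus) for cytotoxicity, read by MTT assay, with stated times of 2 h and 24 h, tested at 1 uM; on this read-out higher numbers stand for a stronger effect at the one concentration tested and lower numbers for a weaker effect. Compound 2 `Oc1cc(C(F)(F)F)ccc1-c1nc(-c2ccccc2O)n(-c2ccc(Br)cc2)n1` gives 69.4% in this assay, and compound 3 `N#Cc1ccc(-n2nc(-c3ccc(C(F)(F)F)cc3O)nc2-c2ccccc2O)cc1` gives 66.6% in this assay. Compound 3 sits between the other two on these numbers: the step is a number 2.2 percentage points higher from compound 1 to compound 3 (within the scatter) and a number 2.8 percentage points lower from compound 2 to compound 3 (within the scatter), so none of the three can be told apart.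

Compound 4 `Oc1cc(C(F)(F)F)ccc1-c1nc(-c2ccccc2O)n(-c2ccccc2F)n1` is not yet measured. It differs from compound 3 by 2-fluorophenyl in place of 4-cyanophenyl on an aromatic nitrogen. For the measured compounds named here, the steps that bear on this change all alter the group on the same aromatic nitrogen: a number 5 percentage points higher from compound 1 to compound 2 (within the scatter), a number 2.2 percentage points higher from compound 1 to compound 3 (within the scatter) and a number 2.8 percentage points lower from compound 2 to compound 3 (within the scatter). Each of them stayed within the scatter, so no step beyond the scatter is expected from compound 3 to compound 4, with the step expected to be a number 0.6 percentage points lower from compound 3 to compound 4 (within the scatter). Compound 4 is therefore estimated to give 66% in this assay, in a range from 55% to 77%.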

Compound 4, a percentage reported as activity, at one concentration (the size of the read-out at that concentration, not a potency): 63.4%
Estimate against measurement, compound 4: 2.6 percentage points above; the range from low to high includes it.
By their numbers in this assay, from the lowest: compounds 4, 1, 3 and 2 (each within the scatter of the next).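

With 2-fluorophenyl on the aromatic nitrogen, compound 4 is the only one of the four that does not carry a 4-substituted phenyl group, yet this assay still does not separate it from the others. The steps are a number 3.2 percentage points lower from compound 3 to compound 4 (within the scatter) and a number 6 percentage points lower from compound 2 to compound 4 (within the scatter) and a number 1 percentage points lower from compound 1 to compound 4 (within the scatter) so all four compounds remain indistinguishable. This position therefore shows no step beyond the scatter with either the 4-substituted phenyl groups or 2-fluorophenyl, and nothing shown here offers an explanation for this.

The compounds shown leave open whether a phenyl group bearing an amine or a carboxylic acid would produce a step beyond the scatter. They also leave open what a straight alkyl chain in place of the aryl group on this nitrogen would do.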